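The source may report more compounds than this note shows. Statements on the series, on what has been measured and on what is new or still open speak of the compounds shown alone.

Compound 1, `CC(=O)SCCC(CCCCC(=O)Nc1cccc(Cl)c1)SC(C)=O`, and compound 2, `CC(=O)SCCC(CCCCC(=O)Nc1ccc(Cl)cc1)SC(C)=O`, share one core and differ only in that 4-chlorophenyl replaces 3-chlorophenyl on an amide-type nitrogen (4-chlorophenyl in place of 3-chlorophenyl on an amide-type nitrogen). In a functional assay on KB cells (Homo sapiens) for inhibition, read by MTT assay, with a stated time of 24 h, tested at 100 ug/mL (a higher number here means more inhibition of growth at the concentration tested, a lower number less inhibition of growth), compound 1 gives 48.8%, while compound 2 gives 72%, a step of a number 23.2 percentage points higher from compound 1 to compound 2 (beyond the scatter). Compound 3, `O=C(CCCCC(CCSC(=O)c1ccccc1)SC(=O)c1ccccc1)Nc1cccc(Cl)c1`, carries a different core; how its core differs from that of compound 1 is not broken down here. In this assay compound 3 was reported as "not active" (no number reported), with no number given. Compound 4, `O=C(CCCCC(CCSC(=O)c1ccccc1)SC(=O)c1ccccc1)Nc1ccc(Cl)cc1`, stands to compound 3 as compound 2 stands to compound 1: the same change, (4-chlorophenyl in place of 3-chlorophenyl on an amide-type nitrogen), at the same place. Since compound 3 gave no measurable activity, the step to compound 4 is expected to be small, and compound 4 is estimated to reach 25%, within 0% to 55%.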

Compound 4, percent growth inhibition at one concentration: 5.78%
Compound 4: middle estimate off by 19.2 percentage points, on the high side, within the range that was stated.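

Going by these compounds alone, compound 3 has no number in this assay, and no step to compound 4 can be read from it. From the compounds shown here alone, whether 4-chlorophenyl in place of 3-chlorophenyl changes inhibition on this core as it does on the core of compound 1 stays open. No measurement shown here bears on the result.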